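A few compounds are considered here, and "the series" means these few. Any claim that something is new, unique, unknown or untested is made for them only; others in the source may bear on it.

Of the compounds shown here, three have been measured in a functional assay on NALM-6 cells (Homo sapiens); a lower number here means a stronger inhibitor, a higher number a weaker inhibitor. Compound 1, `CC(=O)N[C@@H](CSC/C=C(\C)CC/C=C(\C)CCC=C(C)C)C(=O)C=[N+]=[N-]`, gives 30300 nM. Compound 2, `CC(C)=CCC/C(C)=C/CC/C(C)=C/CSC[C@H](NC(=O)OC(C)(C)C)C(=O)C=[N+]=[N-]`, gives 49800 nM. Compound 3, `CCCCCCCCCCCCSC[C@H](NC(C)=O)C(=O)CCl`, gives 2000 nM, the lowest of the three numbers; its distance from compound 1 and from compound 2 lies beyond the usual scatter, so compound 3 is the strongest inhibitor among them.

Compound 1 and compound 2 share one core and differ in a single place, (tert-butoxy in place of methyl on a carbonyl carbon). This change produced a 1.6-fold higher number from compound 1 to compound 2 (0.22 log units; within the scatter), a step that does not stand out from the noise of repeated measurements.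

Compound 4, `CCCCCCCCCCCCSC[C@H](NC(=O)OC(C)(C)C)C(=O)CCl`, has not yet been measured. It is built from compound 3 by the same change, (tert-butoxy in place of methyl on a carbonyl carbon). Compound 3 and compound 1 differ in more than one place, and the difference between the two cores is not broken down here. The place of the change in compound 3 reads word for word as it does in compound 1. This is the same change made on a different core.

Among the compounds with values here, the only guide is the step from compound 1 to compound 2. On that basis, compound 4 is expected to show a step of a 1.4-fold higher number from compound 3 to compound 4 (0.15 log units; within the scatter), because the earlier example gave a 1.6-fold higher number from compound 1 to compound 2 (0.22 log units; within the scatter). Compound 4 is therefore estimated at 2800 nM, with a plausible range from 1200 nM to 7000 nM, on the understanding that a single prior example on a different core is weak evidence.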

Compound 4, half-maximal inhibitory concentration: 15100 nM
The estimate for compound 4 lay 5.4-fold (0.73 log units) below the measured number; the measured number lies above the stated range.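

In this assay, putting tert-butoxy in place of methyl on a carbonyl carbon gave a 7.6-fold higher number from compound 3 to compound 4 (0.88 log units; beyond the scatter), so on the core of compound 3 this change clearly weakens the inhibitor. The same change does not have the same size on the two cores, and a step read on one core therefore cannot be carried over to the other as a fixed number: the same change on two cores in this assay, a 1.6-fold higher number (0.22 log units; within the scatter) from compound 1 to compound 2 and a 7.6-fold higher number (0.88 log units; beyond the scatter) from compound 3 to compound 4, 4.6-fold (0.66 log units) apart, beyond the scatter of two such steps. Within the data shown here, this is only one pair of examples, however, and the two cores differ in more than one place, so the data do not show which of those differences goes with the larger step, why the steps differ, or how the change would behave on any third core.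

The compounds shown leave open how other groups on this carbonyl carbon, such as ethyl, phenyl or benzyloxy, would compare with methyl and tert-butoxy, and whether the step grows in a regular way from one group to the next. They also leave open what a core combining one part of compound 1 with another part of compound 3 would show about which part governs the size of the step.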